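Series notes: the step from compound 1 to compound 4

A few compounds are considered here, and "the series" means these few. Any claim that something is new, unique, unknown or untested is made for them only; others in the source may bear on it.

Measured so far in a functional assay on OVCAR-3 cells (Homo sapiens) for antiproliferative activity, read by MTT assay, with a stated time of 24 h; on this read-out higher numbers stand for weaker inhibition and lower numbers for stronger inhibition:
- compound 1, `O=C(NNc1ccccc1Cl)c1ccccc1NS(=O)(=O)c1cnc(O)nc1O`: 14100 nM
- compound 2, `O=C(NNC(=O)c1ccccc1Cl)c1ccc(NS(=O)(=O)c2cnc(O)nc2O)cc1`: 5220 nM
- compound 3, `O=C(NNC(=O)c1cccc(Cl)c1)c1ccc(NS(=O)(=O)c2cnc(O)nc2O)cc1`: 7710 nM

Compound 1 gives the highest number of the three in this assay. Its gap to compound 2 lies beyond the usual scatter, while compound 1 and compound 3 sit within the scatter of each other. Compound 1 also differs from compound 2 and compound 3 in more than one place, so its values against theirs are read only as they stand, not as a single step.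

Among the measured compounds shown here, the one step that is fully defined, a 1.5-fold higher number from compound 2 to compound 3 (0.17 log units; within the scatter), shows that moving the chlorine on the distal phenyl changes little.

Compound 4, `O=C(NNC(=O)c1ccccc1NS(=O)(=O)c1cnc(O)nc1O)c1ccc(F)cc1`, is not yet measured. It arises from compound 1 by (4-fluorophenyl)carbonyl in place of 2-chlorophenyl on an amine nitrogen. This change brings the amine nitrogen closer in kind to what compound 2 and compound 3 carry, and both of those give lower numbers than compound 1, although the shared core of compound 1 is substituted elsewhere than theirs. For the measured compounds named here, no measured step covers this exact change, so the expectation is loose.

Compound 4 is expected to give a somewhat lower number than compound 1, a step of a 2.0-fold lower number from compound 1 to compound 4 (0.30 log units; within the scatter), with the estimate 7000 nM and a range from 2500 nM to 20000 nM.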

Compound 4, half-maximal inhibitory concentration: 15100 nM
Compound 4: the middle estimate sits 2.2-fold (0.33 log units) below what was measured; measured number inside the range.
By their numbers in this assay, from the lowest: compounds 2, 3, 1 and 4 (each within the scatter of the next, the first and the last beyond it).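

In this assay the amine nitrogen whose other neighbour is an amide-type nitrogen takes (4-fluorophenyl)carbonyl in place of 2-chlorophenyl, and the outcome is a 1.1-fold higher number from compound 1 to compound 4 (0.03 log units; within the scatter) so the two compounds stand level on this read-out. Among the compounds shown here, this is the first defined step at this position, and it shows that exchanging a directly attached halogenated phenyl for a halogenated phenyl carried on a carbonyl leaves the number unresolved from that of compound 1 on this shared core. Nothing at hand explains why the number holds across this change.

For the compounds shown here, the step changes the carbonyl, the halogen and the halogen's place on the phenyl all at once, so the single comparison cannot assign any part of the outcome to one of these features or show whether they offset each other. Also open, going by these compounds, is whether a group without an aromatic ring on this amine nitrogen, such as acetyl, a longer alkyl chain or a chain ending in a carboxylic acid, would give a step beyond the scatter.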